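Phenyl for trifluoromethyl: notes on compound 3

This account rests on a few compounds, and the source may have more. Where it says the series, first, only, none or still open, it means among the compounds named here.

In a functional assay on a cell-free system (Platelet, plasma, Homo sapiens) for inhibition (on this read-out higher numbers stand for weaker inhibition and lower numbers for stronger inhibition), compound 1 (`Cc1ccc(N(CCN2CCC(OCC(=O)O)CC2)C(=O)c2ccc(F)cc2)cc1`) gives 970 nM as its value. Compound 2 (`Cc1ccc(N(CCN2CCC(OCC(=O)O)CC2)C(=O)c2ccc(C(F)(F)F)cc2)cc1`) stands at > 10000 nM on the same read-out, and this is a limit of the assay, not a number.

Going by the values given here, the one measured step that bears on the next change is an at least 10-fold higher number from compound 1 to compound 2 (1.01 log units; beyond the scatter) with trifluoromethyl in place of fluoro on an aromatic carbon. From the compounds shown here alone, it is a large step, and its true size stays open since it ends at a limit.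

Compound 3 (`Cc1ccc(N(CCN2CCC(OCC(=O)O)CC2)C(=O)c2ccc(-c3ccccc3)cc2)cc1`) carries phenyl in place of trifluoromethyl on an aromatic carbon, para to a large group: phenyl in place of trifluoromethyl on an aromatic carbon is the counted difference. Among the compounds with values here, no measured step covers phenyl at this place. Within the data shown here, with only the step from fluoro as a guide, inhibition in this assay is expected to stay weak, with no defined move in either direction, though a partial return toward compound 1 cannot be excluded.

The step expected here is a number no higher from compound 2 to compound 3 (the limit leaves the size open) as an estimate only. For compound 3 the estimated value is 10000 nM with an expected range from 2500 nM to 40000 nM in this assay, and a report as a limit alone is quite likely.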

Compound 3, half-maximal inhibitory concentration: > 10000 nM
Compound 3 gave a limit, no number (the forecaster's own chance of this, stated with the estimate: 65%); the middle value sits exactly at the limit.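

Compound 3 stands at > 10000 nM in this assay, and this is a limit, not a number. Phenyl in place of fluoro gives an at least 10-fold higher number from compound 1 to compound 3 (1.01 log units; beyond the scatter) and so adds a second replacement of fluoro at this place, on an aromatic carbon para to a large group, that ends at the limit; of the three compounds, only compound 1 keeps a number in this series. The step from compound 2 to compound 3 cannot be read, because both compounds end at the same limit: the limit of > 10000 nM in this assay, at which 2 of the 3 values shown sit.

From the compounds shown here alone, how far compound 2 and compound 3 lie past that limit stays open, so trifluoromethyl and phenyl cannot be put in order, and a group of six heavy atoms cannot be told apart from one of four on this read-out. Going by these compounds, it also stays open whether hydrogen, chlorine, methoxy or nitrile at this place would give a number near that of compound 1, or whether a carboxylic acid or an amine on the added ring would bring a number back.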